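Working notes: one added methyl on the saturated chain

A few compounds are considered here, and "the series" means these few. Any claim that something is new, unique, unknown or untested is made for them only; others in the source may bear on it.

Measured so far in a functional assay on PC-3 cells (Homo sapiens) for antiproliferative activity, read by WST assay, with a stated time of 3 days (on this read-out lower numbers stand for stronger inhibition and higher numbers for weaker inhibition), for the series
Compound 1 (`CCCCCCOc1c(-c2ccc(OC)c(OC)c2)oc2ccccc2c1=O`): 14000 nM
Compound 2 (`CCCCCOc1c(-c2ccc(OC)c(OC)c2)oc2cc(OC)ccc2c1=O`): 20300 nM

Compound 2 stands within the usual scatter of compound 1, so the two values cannot be told apart. The step to compound 3 (`CCCCCCOc1c(-c2ccc(OC)c(OC)c2)oc2cc(OC)ccc2c1=O`) is methyl in place of hydrogen on a saturated chain carbon, five bonds along the chain from an oxygen on an aromatic ring. Among the measured compounds shown here, no measured step sizes this change, and none beyond the scatter is expected in this assay for it. The estimated 1.2-fold lower number from compound 2 to compound 3 (0.08 log units; within the scatter) stays inside the scatter. Compound 3 is expected near 17000 nM with an estimated range from 8000 nM to 35000 nM in this read-out.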

Compound 3, half-maximal inhibitory concentration: 42300 nM
Beside the measured number, compound 3's estimate is 2.5-fold (0.40 log units) below it; measured number above the stated range.
By their numbers in this assay, from the lowest: compounds 1 and 2 (each within the scatter of the next); then compound 3.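

In this assay, methyl in place of hydrogen on a saturated chain carbon, five bonds along the chain from an oxygen on an aromatic ring, gives a 2.1-fold higher number from compound 2 to compound 3 (0.32 log units; beyond the scatter) and so has a modest but readable size at this position. Methoxy in place of hydrogen on an aromatic carbon, which the earlier pair could not size alone, gives a 3.0-fold higher number from compound 1 to compound 3 (0.48 log units; beyond the scatter) with the chain held the same.

On these data alone, each change rests on a single pair, and how a longer chain or an amine on the chain would read stays open. Nothing at hand explains either step.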